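One Aromatic Group Exchanged on Compound 1

The compounds below may be only part of what the source reports. "The series", "measured", "known", "first", "only" and "open" are said of these compounds alone.

Compound 1 (`CC#CCn1c(N2CCC[C@@H](N)C2)nc2c1c(=O)n(CCCN1CCN(c3nc(-c4ccccc4)cs3)CC1)c(=O)n2C`) gives 68.3%
Compound 2 (`CC#CCn1c(N2CCC[C@@H](N)C2)nc2c1c(=O)n(CCCN1CCC(n3cc(-c4ccccc4)nn3)CC1)c(=O)n2C`) gives 21%

In an ADME assay on cells (Hepatocyte, Mus musculus, strain ICR/CD-1) for metabolic stability, read by LC-MS, with a stated time of 30 min (on this read-out lower numbers stand for a less stable compound and higher numbers for a more stable compound), compound 1 stands highest of the two numbers, and compound 2 lies lower by a gap beyond the usual scatter. Compound 3 (`CC#CCn1c(N2CCC[C@@H](N)C2)nc2c1c(=O)n(CCCN1CCN(c3noc(-c4ccccc4)n3)CC1)c(=O)n2C`) keeps the shared core of compound 1 and exchanges one group: 5-phenyl-1,2,4-oxadiazol-3-yl in place of 4-phenyl-1,3-thiazol-2-yl on an amine nitrogen in a ring. Among the compounds with values here, no measured pair isolates this exchange, so the forecast is rough. Compound 2 reads 21% with a different group in that part of the molecule, which leaves room for a fall. A moderate fall is expected, estimated as a number 20.3 percentage points lower from compound 1 to compound 3 (beyond the scatter) in this assay and uncertain in size. Compound 3 is estimated at 48% with an expected span from 22% to 72% across repeat measurements.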

Compound 3, percent of the compound remaining: 24.2%
Estimate against measurement, compound 3: 23.8 percentage points above; the measured number falls inside the stated range.
By their numbers in this assay, from the lowest: compounds 2 and 3 (each within the scatter of the next); then compound 1.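

Within the data shown here, this is the first pair of compounds that differ in one place only, the group on an amine nitrogen in a ring. In this assay, exchanging 4-phenyl-1,3-thiazol-2-yl for 5-phenyl-1,2,4-oxadiazol-3-yl gives a number 44.1 percentage points lower from compound 1 to compound 3 (beyond the scatter). The position is therefore sensitive to this change, even though both groups have 11 heavy atoms and each joins a five-membered aromatic ring to a six-membered aromatic ring of carbon only; nothing at hand explains the drop.

Going by these compounds, it remains open whether the loss follows from the five-membered ring itself or from how the phenyl ring is attached to it. Also open, on these data alone, is how the number would move with an amine or a carboxylic acid on that phenyl ring.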